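Swapping Chloro for Trifluoromethyl on Compound 2

A few compounds are considered here, and "the series" means these few. Any claim that something is new, unique, unknown or untested is made for them only; others in the source may bear on it.

Compound 2 `Cc1ccc(S(=O)(=O)c2nc3ccccc3nc2Nc2ccc(Cl)cc2)cc1` gives 9660 nM in a functional assay on PC-3 cells (Homo sapiens) for cytotoxicity, read by MTT assay, with a stated time of 72 h (a higher number here means a weaker inhibitor, a lower number a stronger inhibitor), the higher of the two numbers measured, while compound 1 `COc1cc(Nc2nc3ccccc3nc2S(=O)(=O)c2ccc(C)cc2)cc(OC)c1` gives 2940 nM. Among the compounds with values here, the only measured step, a 3.3-fold higher number from compound 1 to compound 2 (0.52 log units; beyond the scatter), replaced the whole ring on the nitrogen, so it does not speak directly to a swap of one group. Compound 3 `Cc1ccc(S(=O)(=O)c2nc3ccccc3nc2Nc2ccc(C(F)(F)F)cc2)cc1` differs from compound 2 by trifluoromethyl in place of chloro on an aromatic carbon. Within the data shown here, with no step of this kind measured, compound 3 is expected to land near compound 2, at an estimated 9000 nM with a range from 3000 nM to 27000 nM. The expected step, a 1.1-fold lower number from compound 2 to compound 3 (0.03 log units; within the scatter), stays within the scatter.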

Compound 3, half-maximal inhibitory concentration: 2540 nM
Estimate against measurement, compound 3: 3.5-fold (0.55 log units) above; the whole stated range lies above it.
By their numbers in this assay, from the lowest: compounds 3 and 1 (each within the scatter of the next); then compound 2.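

In this assay, a swap of one small group on the aromatic carbon is enough to shift the number: a 3.8-fold lower number from compound 2 to compound 3 (0.58 log units; beyond the scatter), something the earlier whole-ring step could not show. With trifluoromethyl in place, 4-(trifluoromethyl)phenyl and 3,5-dimethoxyphenyl cannot be told apart, with a 1.2-fold lower number from compound 1 to compound 3 (0.06 log units; within the scatter). Nothing available explains why trifluoromethyl and chloro differ here.

On these data alone, it remains open how an amine or a carboxylic acid would behave on this same aromatic carbon. Also open, as far as these compounds go, is whether trifluoromethyl in place of chloro would give a similar step on a different core.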